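The compounds below may be only part of what the source reports. "The series", "measured", "known", "first", "only" and "open" are said of these compounds alone.

Two compounds measured in a functional assay on HepG2 cells (Homo sapiens) for cytotoxicity, read by sulforhodamine B assay, with a stated time of 48 h (on this read-out lower numbers stand for stronger inhibition and higher numbers for weaker inhibition), set the scene. Compound 1 `CSC(SC)=C(C#N)C(=O)N/N=C(\C)c1ccc(NS(=O)(=O)c2ccc(Cl)cc2)cc1` gives 19400 nM in this assay. Compound 2 `CCOC(=O)c1c(-c2ccc(C)cc2)c(C#N)c(=O)n(/N=C(\C)c2ccc(NS(=O)(=O)c3ccc(Cl)cc3)cc2)c1N` gives 8380 nM in this assay, the lower of the two numbers, and compound 1 stands higher by a margin beyond the usual scatter. Compound 3 `CCOC(=O)c1c(-c2cccc([N+](=O)[O-])c2)c(C#N)c(=O)n(/N=C(\C)c2ccc(NS(=O)(=O)c3ccc(Cl)cc3)cc2)c1N` is not yet measured. It differs from compound 2 in one place: 3-nitrophenyl in place of 4-methylphenyl on an aromatic carbon. For the measured compounds named here, no measured pair shows what such a swap does on its own, so the expectation rests only on compound 2 and on the change itself. The step expected here, a 1.0-fold higher number from compound 2 to compound 3 (0.01 log units; within the scatter), is small and could go either way, most likely not beyond the scatter. On that basis compound 3 is expected to give about 8500 nM in this assay. The estimated range for compound 3 runs from 3000 nM to 25000 nM, with only a small chance that the assay reports a limit rather than a number.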

Compound 3, half-maximal inhibitory concentration: 29700 nM
The estimate for compound 3 lay 3.5-fold (0.54 log units) below the measured number; measured number outside the range, above it.
By their numbers in this assay, from the lowest: compound 2; then compounds 1 and 3 (each within the scatter of the next).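

In this assay the aromatic carbon opposite the ring nitrogen proves sensitive to the group it carries: 3-nitrophenyl in place of 4-methylphenyl gives a weaker result (a 3.5-fold higher number from compound 2 to compound 3 (0.55 log units; beyond the scatter)), a modest step but one beyond the scatter. Compound 2 alone could not show that this position responds to such a swap, or in which direction this particular change would go. No measurement here explains why the number rises.

The swap changes both the substituent and where it sits on the phenyl ring, so the compounds shown cannot separate the effect of the nitro group from that of its placement. Open too, going by these compounds, is how a plain phenyl, 3-methylphenyl or 4-nitrophenyl group would behave at this position.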